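From furan-2-yl to 4-nitrophenyl on a shared core

A few compounds are considered here, and "the series" means these few. Any claim that something is new, unique, unknown or untested is made for them only; others in the source may bear on it.

Three measured compounds share one core and differ only in the group on a double-bonded chain carbon. In a functional assay, read by spectrophotometry, tested at 100 uM (on this read-out lower numbers stand for stronger inhibition and higher numbers for weaker inhibition), compound 1 (`O=C(/C=C/c1cccs1)c1cccc(NC(=O)c2cc(-c3ccncc3)n[nH]2)c1`) gives 27600 nM. Compound 2 (`COc1ccc(/C=C/C(=O)c2cccc(NC(=O)c3cc(-c4ccncc4)n[nH]3)c2)cc1`) gives 38400 nM. Compound 3 (`O=C(/C=C/c1ccco1)c1cccc(NC(=O)c2cc(-c3ccncc3)n[nH]2)c1`) gives 41800 nM, a number within the usual scatter of both others, so it does not stand apart from them.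

Compound 4 (`O=C(/C=C/c1ccc([N+](=O)[O-])cc1)c1cccc(NC(=O)c2cc(-c3ccncc3)n[nH]2)c1`) has not yet been measured. It carries 4-nitrophenyl in place of furan-2-yl on a double-bonded chain carbon bound to a double-bonded chain carbon.

The closest guide is a 1.1-fold higher number from compound 2 to compound 3 (0.04 log units; within the scatter), which also exchanges a substituted six-membered aromatic ring and furan-2-yl, in the opposite direction. The other two measured steps are a 1.4-fold higher number from compound 1 to compound 2 (0.14 log units; within the scatter) and a 1.5-fold higher number from compound 1 to compound 3 (0.18 log units; within the scatter). Among the measured compounds shown here, all three changes at this place stay within the scatter, although no measured compound carries a nitro group, so the new group itself remains untested. No step beyond the scatter is therefore expected in this assay.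

The estimated change is a 1.2-fold lower number from compound 3 to compound 4 (0.08 log units; within the scatter).

The expected value for compound 4 is 35000 nM, with an estimated range from 15000 nM to 80000 nM.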

Compound 4, half-maximal inhibitory concentration: 52800 nM
Compound 4: middle estimate off by 1.5-fold (0.18 log units), on the low side; low and high end bracket the measured number.
By their numbers in this assay, from the lowest: compounds 1, 2, 3 and 4 (each within the scatter of the next).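

In this assay, among the compounds shown here, the first nitro group at this place does not set compound 4 apart: 4-nitrophenyl in place of furan-2-yl stays within the scatter (a 1.3-fold higher number from compound 3 to compound 4 (0.10 log units; within the scatter)), and so does nitro in place of methoxy on an aromatic carbon (a 1.4-fold higher number from compound 2 to compound 4 (0.14 log units; within the scatter)). Even the largest step among the four compounds lies within the scatter (a 1.9-fold higher number from compound 1 to compound 4 (0.28 log units; within the scatter)), so thiophen-2-yl, furan-2-yl, 4-methoxyphenyl and 4-nitrophenyl cannot be told apart on a double-bonded chain carbon bound to a double-bonded chain carbon, and a nitro group joins the range of groups that read alike here. No measurement of any property of these groups is at hand to account for this result.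

Going by these compounds, all four compounds carry an aromatic ring at this place, so it remains open whether a group without one, such as an amine, a carboxylic acid or a longer saturated carbon chain, would give a number beyond the scatter. On these data alone, it also remains open how the numbers would respond to a change elsewhere on the shared core, such as a methyl group in place of the amide hydrogen.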